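Turning One Stereocentre of Compound 1

The source may report more compounds than this note shows. Statements on the series, on what has been measured and on what is new or still open speak of the compounds shown alone.

For the measured compounds named here, compound 1 `COc1ccc(/C=C/[C@@](C)(/C=C/c2ccc(O)cc2)CCC=C(C)C)cc1` stands highest of the two compounds measured so far in a functional assay on PC-3 cells (Homo sapiens) for inhibition, with a stated time of 48 h, tested at 50 uM (a higher number here means more inhibition of growth at the concentration tested, a lower number less inhibition of growth), where compound 1 gives 50%. Compound 2 `COc1ccc(/C=C/[C@@](C)(/C=C/c2ccc(O)cc2)CCC=C(C)C)cc1C=O` bears an extra formyl group, and compound 2 gives 34%. That single edit produces a number 16 percentage points lower from compound 1 to compound 2 (beyond the scatter).

Compound 3 `COc1ccc(/C=C/[C@](C)(/C=C/c2ccc(O)cc2)CCC=C(C)C)cc1` is a different kind of variation: the two compounds have the same atoms and bonds and differ only in configuration as drawn: 1 of 3 stereo elements differ; a stereocentre at a saturated chain carbon is drawn R in compound 1 and S in compound 3. Going by the values given here, no measured step tests a change of configuration. The formyl step swaps a group instead, so it serves only as a rough yardstick for how far one edit can move the number in this assay. With nothing to indicate a direction, the expectation is no step beyond the scatter, although the range must stay wide enough to allow for a real difference between the two configurations. The expected change is a number 2 percentage points lower from compound 1 to compound 3 (within the scatter). For compound 3, the estimated growth inhibition is 48%, with an expected range from 34% to 60%.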

Compound 3, percent growth inhibition at one concentration: 93%
Estimate against measurement, compound 3: 45 percentage points below; the measured number lies above the stated range.
By their numbers in this assay, from the lowest: compound 2; then compound 1; then compound 3.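

In this assay, the configuration of the stereocentre at a saturated chain carbon proves to matter a great deal: going from R to S gives a number 43 percentage points higher from compound 1 to compound 3 (beyond the scatter), although no atom or bond is added or removed. The earlier formyl step, a number 16 percentage points lower from compound 1 to compound 2 (beyond the scatter), exchanged a hydrogen for a group on an aromatic carbon, whereas this larger step shows that the arrangement at one chain carbon can move the number without any change of groups. The step can be assigned to that single stereocentre, because the pair offers no other difference to explain it: the fact that compounds 1 and 3 differ only in the configuration as drawn.

The compounds shown do not reveal how the S configuration produces this gain, or whether a formyl group would lower the number on the S form as it does on the R form. Going by these compounds, it also remains open whether an amine or a carboxylic acid on the aromatic carbon that carries the formyl group in compound 2 would keep the high number seen with compound 3.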